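The compounds below may be only part of what the source reports. "The series", "measured", "known", "first", "only" and "open" are said of these compounds alone.

In an ADME assay on J774.A1 cells (Mus musculus) for inhibition, read by MTT assay, with a stated time of 72 h (on this read-out higher numbers stand for an effect only at larger amounts of compound and lower numbers for an effect already at smaller amounts), compound 1 `CNc1nc(NC(C)C)nc2ccccc12` has the entry "not determined" (no result reported), so it offers no number. Compound 2 `CC(C)Nc1nc(NCC2CCCO2)c2ccccc2n1` gives 46000 nM. Compound 3 `CC(C)Nc1nc(NC(C)C)c2ccccc2n1` gives > 30000 nM, which is a limit of the assay and not a number. Compound 4 `CC(C)Nc1nc(NCc2ccco2)nc2ccccc12` has not been measured yet. It carries (furan-2-yl)methyl in place of isopropyl on a nitrogen on an aromatic ring. For the measured compounds named here, the one measured step that bears on this change is a step that the limit leaves unreadable from compound 2 to compound 3, where isopropyl takes the place of (oxolan-2-yl)methyl on such a nitrogen. The evidence on that step is the limit of > 30000 nM in this assay, at which 1 of the 3 values shown sits. Going by the values given here, it therefore supplies no size to carry over, and compound 2 at 46000 nM remains the only true number nearby. No change beyond the scatter is expected in this assay, in either direction. The expected step is a step that the limit leaves unreadable from compound 3 to compound 4, and this is only an estimate. Compound 4 is expected at 40000 nM, with an estimated range from 15000 nM to 90000 nM.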

Compound 4, half-maximal effective concentration: 8300 nM
Beside the measured number, compound 4's estimate is 4.8-fold (0.68 log units) above it; measured number below the stated range.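

In this assay, for the compounds shown here, this nitrogen on an aromatic ring turns out to be a place where the substituent matters: (furan-2-yl)methyl in place of isopropyl gives an at least 3.6-fold lower number from compound 3 to compound 4 (0.55 log units; beyond the scatter) and so yields the first readable change in this small set, while the earlier step cannot be read. The effect now appears at smaller amounts of compound with the entering group, which brings a five-membered aromatic ring and a hydrogen-bond acceptor, though nothing shown says why. The size of this step is a minimum and not an exact figure: the limit of > 30000 nM in this assay, at which 1 of the 4 values shown sits.

The compounds shown leave open whether the aromatic ring matters or simply the larger group, which a benzyl or a plain butyl chain on this nitrogen could help separate. They also leave open what the ring oxygen contributes, a question that a (thiophen-2-yl)methyl group could address.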